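The source may hold more compounds than are shown below. What is called first, only, known or untested is meant among the compounds shown, and "the series" means these compounds.

Compound 1, `Nc1nc(Cl)c2ncn(Cc3ccccc3CCl)c2n1`, carries a chloromethyl arm on the benzyl group and sits alongside two relatives with the same arm placed elsewhere on the ring. In a functional assay on RXF 393 cells (Homo sapiens) for cytotoxicity, read by sulforhodamine B assay, with a stated time of 48 h (a higher number here means a weaker inhibitor of growth, a lower number a stronger inhibitor of growth), compound 1 itself gives "not determined" (no result reported), so no single number is available for it. Its companions do give numbers. In this assay compound 2, `Nc1nc(Cl)c2ncn(Cc3ccc(CCl)cc3)c2n1`, gives 7240 nM, and compound 3, `ClCc1cccc(Cn2cnc3nc(Cl)nc(Cl)c32)c1`, which carries a second chloro group on the shared core, gives 2630 nM. The two values lie within the usual scatter of one another, so nothing can be read into their order.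

The step from compound 1 leads to compound 4, `ClCc1ccccc1Cn1cnc2c(Cl)ncnc21`. The change is hydrogen in place of amino on an aromatic carbon. Among the compounds with values here, with no measured pair of this kind among the compounds above, the size of the step in this assay cannot be taken from data; the expectation is for no change beyond the scatter, or at most a modest weakening, since both measured relatives sit in the same low micromolar band and the core change in compound 3 did not move the value beyond the scatter.

Compound 4 is therefore expected to give about 6000 nM, within a range from 1800 nM to 20000 nM.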

Compound 4, concentration for total growth inhibition: 2340 nM
The estimate for compound 4 lay 2.6-fold (0.41 log units) above the measured number; the range from low to high includes it.
By their numbers in this assay, from the lowest: compounds 4 and 3 (each within the scatter of the next); then compound 2.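

In this assay compound 4 gives 2340 nM, while compound 1 has no single number, so the step between them cannot be read. Nothing shown offers an explanation for the value of compound 4. The compounds shown leave open what hydrogen in place of amino does in this assay, and whether the placing of the chloromethyl arm matters.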